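The compounds below may be only part of what the source reports. "The series", "measured", "known", "first", "only" and "open" are said of these compounds alone.

Of the compounds shown here, three built on one shared core have been read in a functional assay on K562 cells (Homo sapiens) for cytotoxicity, read by MTT assay, with a stated time of 48 h; on this read-out higher numbers stand for weaker inhibition and lower numbers for stronger inhibition. In this assay, compound 1 `O=C(CN[C@H]1CCN(S(=O)(=O)Cc2ccccc2)C1)N1CCN(Cc2ccc(Cl)cc2)CC1` gives 9200 nM, compound 2 `O=C(CN[C@H]1CCN(S(=O)(=O)Cc2ccccc2)C1)N1CCN(Cc2cccc(F)c2)CC1` gives 13200 nM and compound 3 `O=C(CN[C@H]1CCN(S(=O)(=O)Cc2ccccc2)C1)N1CCN(Cc2cccc(C(F)(F)F)c2)CC1` gives 3600 nM. Compound 3 thus has the lowest number of the three, and it stands apart from both others beyond the scatter: a 2.6-fold lower number from compound 1 to compound 3 (0.41 log units; beyond the scatter) and a 3.7-fold lower number from compound 2 to compound 3 (0.56 log units; beyond the scatter). The two others do not separate, with a 1.4-fold higher number from compound 1 to compound 2 (0.16 log units; within the scatter).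

The unmeasured compound 4 `O=C(CN[C@H]1CCN(S(=O)(=O)Cc2ccccc2)C1)N1CCN(Cc2c(F)cccc2Cl)CC1` keeps the core of compound 3 but changes the aryl group: 2-chloro-6-fluorophenyl in place of 3-(trifluoromethyl)phenyl on a saturated chain carbon bound to an amine nitrogen in a ring. It carries 2-chloro-6-fluorophenyl in place of 3-(trifluoromethyl)phenyl on a saturated chain carbon bound to an amine nitrogen in a ring. Within the data shown here, no measured compound carries this exact group, so the nearest guides are the steps at the same place. Compound 1 and compound 2 also lack trifluoromethyl and bear only chloro or fluoro, and they sit above compound 3 by the modest steps already shown. Compound 4 is therefore expected to move back toward them, and a modest rise is expected, estimated as a 2.2-fold higher number from compound 3 to compound 4 (0.35 log units; beyond the scatter). The estimate for compound 4 is 8000 nM, with an expected range from 3500 nM to 18000 nM.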

Compound 4, half-maximal inhibitory concentration: 65800 nM
Compound 4: the middle estimate sits 8.2-fold (0.92 log units) below what was measured; measured number above the stated range.
By their numbers in this assay, from the lowest: compound 3; then compounds 1 and 2 (each within the scatter of the next); then compound 4.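

In this assay, among these compounds, this position proves far more sensitive than the first three compounds showed: the earlier steps here were modest or within the scatter, whereas the move to 2-chloro-6-fluorophenyl gives an 18-fold higher number from compound 3 to compound 4 (1.26 log units; beyond the scatter), the only large step in the set. The result also shows that lacking trifluoromethyl does not by itself place a compound level with the 4-chlorophenyl and 3-fluorophenyl compounds, since 2-chloro-6-fluorophenyl also stands well clear of them, with a 7.2-fold higher number from compound 1 to compound 4 (0.85 log units; beyond the scatter) and a 5.0-fold higher number from compound 2 to compound 4 (0.70 log units; beyond the scatter), so the four aryl groups now span a much wider range of numbers than the first three did. There is no evidence at hand that bears on this rise, so the data describe its size and leave its cause unexplained.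

The compounds shown cannot tell whether the chloro, the fluoro or the two together in 2-chloro-6-fluorophenyl account for the rise. Going by these compounds, how a methoxy group on the aryl ring, or a longer chain in place of the benzyl carbon, would read at this position also remains open.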